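Replacing Nitrophenyl with Propyl on an Acylthiourea

This account rests on a few compounds, and the source may have more. Where it says the series, first, only, none or still open, it means among the compounds named here.

Measured so far:
Compound 1 `NC(=S)N1CCCc2c(OCCCCCOc3cccc4ccccc34)cccc21` gives > 50000 nM in an ADME assay on Huh-7 cells (Homo sapiens) for cytotoxicity (on this read-out lower numbers stand for higher toxicity in this test and higher numbers for lower toxicity in this test), which is a limit of the assay rather than a number.
Compound 2 `O=C(NC(=S)N1CCc2c(OCCCCCOc3ccc(Cl)cc3)cccc21)c1ccc([N+](=O)[O-])cc1` gives 13600 nM in this assay.

Among the measured compounds shown here, compound 2 therefore stands as the only actual number in this assay; the other entry is a limit. Compound 1, which carries no carbonyl group on its thiourea, sits at the limit (the limit of > 50000 nM in this assay, at which 1 of the 2 values shown sits). Compound 3 `CCCC(=O)NC(=S)N1CCc2c(OCCCCCOc3ccc(Cl)cc3)cccc21` differs from compound 2 in one place: propyl in place of 4-nitrophenyl on a carbonyl carbon. For the measured compounds named here, no step between two measured compounds is known here, so the size of this step can only be expected, not read off. Since compound 1 reaches the limit (the limit of > 50000 nM in this assay, at which 1 of the 2 values shown sits), the expectation for the move toward a propyl group is a step of a 2.2-fold higher number from compound 2 to compound 3 (0.34 log units; beyond the scatter) upward in this assay, beyond the usual scatter and toward lower toxicity, although a result within the scatter cannot be excluded. Compound 3 is thus estimated at 30000 nM, with a range from 10000 nM to 100000 nM, and a real chance that only the limit is reported.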

Compound 3, half-maximal cytotoxic concentration: > 50000 nM
Compound 3: only a limit was reported; the forecaster's own chance of this, stated with the estimate: 40%; at least 1.6-fold (0.22 log units) between middle value and limit.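

Among the compounds shown here, exchanging 4-nitrophenyl for propyl on a carbonyl carbon gives the first direct comparison at this position in this assay, and it is clear: an at least 3.6-fold higher number from compound 2 to compound 3 (0.56 log units; beyond the scatter). With everything else in the molecule held the same, the group at this one place is enough to separate a measurable value from the end of the read-out. Compound 2 is now the only one of the three compounds with an actual number, while the other two sit at a limit: the limit of > 50000 nM in this assay, at which 2 of the 3 values shown sit.

Going by these compounds, the true size of the step stays open, as does the question of which part of 4-nitrophenyl matters, the nitro group or the aromatic ring itself. A plain phenyl group on the same carbonyl carbon would tell these two apart, and a longer chain such as octyl would show whether the result for propyl extends to other chains.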